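Compound 2 at the limit of a cytotoxicity read-out

The source may hold more compounds than are shown below. What is called first, only, known or untested is meant among the compounds shown, and "the series" means these compounds.

Of the compounds shown here, two have so far been tested in a functional assay on HFF cells (Homo sapiens) for cytotoxicity; on this read-out lower numbers stand for stronger inhibition and higher numbers for weaker inhibition. Compound 1 (`O=S(=O)(NN1C(=S)S/C(=C\c2ccc(Cl)c(Cl)c2)C1O)c1ccc(Cl)cc1`) gives > 100000 nM, which is a limit of the assay and not a number. Compound 2 (`O=C1/C(=C/c2ccc([N+](=O)[O-])cc2)SC(=S)N1NS(=O)(=O)c1ccccc1`) gives > 100000 nM, which is likewise a limit. Compound 2 therefore has no number of its own and stands at the limit of > 100000 nM in this assay, at which 2 of the 2 values shown sit.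

Compound 3 (`O=C1/C(=C/c2cc(F)c(F)cc2F)SC(=S)N1NS(=O)(=O)c1ccccc1`) has not yet been measured. It differs from compound 2 in one place, with 2,4,5-trifluorophenyl in place of 4-nitrophenyl on a double-bonded chain carbon bound to a double-bonded ring carbon.

For the measured compounds named here, no measured pair shows what such an exchange does in this assay, so the expectation has only one anchor. That anchor is compound 2 at > 100000 nM, and a limit gives no exact starting point. No change beyond the usual scatter is expected, and the estimated step is a number no higher from compound 2 to compound 3 (the limit leaves the size open). For compound 3 the expected value is 100000 nM, with an estimated range of 40000 nM to 200000 nM, and the assay may well report only a limit again.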

Compound 3, half-maximal inhibitory concentration: > 100000 nM
Compound 3: only a limit was reported (the forecaster's own chance of this, stated with the estimate: 80%); the middle value sits exactly at the limit.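

In this assay compound 3 gives > 100000 nM, which is a limit and not a number. No step can be read between compound 2 and compound 3, and the three compounds share one position: the limit of > 100000 nM in this assay, at which 3 of the 3 values shown sit.

The compounds shown leave open how 4-nitrophenyl and 2,4,5-trifluorophenyl compare, and where any of these compounds would give an actual number on this read-out.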